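The compounds below may be only part of what the source reports. "The series", "measured", "known", "first", "only" and "open" are said of these compounds alone.

Measured compounds:
- compound 2 `CN1CCC(n2cc(S(=O)(=O)c3cccc(F)c3)c3ccccc32)C1`: 49%
- compound 3 `O=S(=O)(c1cccc(Cl)c1)c1cn(C2CCNC2)c2ccccc12`: 48%
- compound 1 `O=S(=O)(c1cccc(F)c1)c1cn(C2CCNC2)c2cccc(F)c12`: "not determined" (no result reported)

In a functional assay on HeLa cells for agonist activity at 5-hydroxytryptamine receptor 6 (Homo sapiens), read by cAMP accumulation and immunoassay, with a stated time of 10 min (on this read-out higher numbers stand for larger maximal responses and lower numbers for smaller maximal responses), compound 3 gives 48%. Within the data shown here, only one other number exists for comparison: in this assay compound 2 gives 49%, which lies within the scatter of the value of compound 3, so the two cannot be told apart. Compound 1 has no result in this assay.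

Compound 4 `O=S(=O)(c1cccc(F)c1)c1cn(C2CCNC2)c2ccccc12` differs from compound 3 in one place: fluoro in place of chloro on an aromatic carbon. Among the measured compounds shown here, no measured pair shows what this exchange does, so the expected step is small and not beyond the scatter. The value of compound 4 is therefore estimated at 48%, with a range from 36% to 60%, a step of no change at the digits printed from compound 3 to compound 4 (within the scatter).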

Compound 4, largest response reached (Emax), in percent of the reference or control that the assay uses: 38%
For compound 4 the middle estimate is 10 percentage points above the measured one; the measured number falls inside the stated range.
By their numbers in this assay, from the lowest: compounds 4, 3 and 2 (each within the scatter of the next, the first and the last beyond it).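

In this assay, fluoro in place of chloro on the aromatic ring gives a number 10 percentage points lower from compound 3 to compound 4 (within the scatter) and so cannot be told apart from no change. Hydrogen in place of methyl on the ring amine nitrogen gives a number 11 percentage points lower from compound 2 to compound 4 (beyond the scatter) and is the first step here that exceeds the usual variation, though only modestly. No available data explain either step. The compounds shown leave open how a methoxy group or a nitrile at this aromatic position would affect the maximal response. They also leave open the effect of an ethyl group on the ring nitrogen.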